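The source may report more compounds than this note shows. Statements on the series, on what has been measured and on what is new or still open speak of the compounds shown alone.

The series shares the core of compound 1 `Cc1ccc(OCC(=O)N(C)Cc2cccs2)cc1` and varies only the group on the amide-type nitrogen. In an assay on HEK293 cells for agonist activity at transient receptor potential cation channel subfamily M member 8 (Homo sapiens), read by fluorescence and calcium flux, with a stated time of 15 min (a lower number here means that less compound is needed, a higher number that more compound is needed for the effect), compound 1 gives 400 nM. Compound 2 `Cc1ccc(OCC(=O)N(Cc2cccs2)c2ccncc2)cc1` gives 52 nM in this assay, and compound 3 `Cc1ccc(OCC(=O)N(Cc2cccs2)c2nccn2C)cc1` gives 1790 nM. Compound 3 thus stands highest of the three numbers: the nearest is compound 1, with a 4.5-fold higher number from compound 1 to compound 3 (0.65 log units; beyond the scatter), and the furthest is compound 2, with a 34-fold higher number from compound 2 to compound 3 (1.54 log units; beyond the scatter). Compound 4 `Cc1ccc(OCC(=O)N(Cc2cccs2)c2ccn[nH]2)cc1` differs from compound 3 at the same position: 1H-pyrazol-5-yl in place of 1-methyl-1H-imidazol-2-yl on an amide-type nitrogen. Among the measured compounds shown here, the steps that bear on this change are the ones that also exchange the group on the amide-type nitrogen, namely a 7.7-fold lower number from compound 1 to compound 2 (0.89 log units; beyond the scatter), a 4.5-fold higher number from compound 1 to compound 3 (0.65 log units; beyond the scatter) and a 34-fold higher number from compound 2 to compound 3 (1.54 log units; beyond the scatter). Exchanges there have moved the number by modest to large amounts in both directions, and no measured step trades one five-membered ring for another, so the direction is uncertain. A modest lowering is nevertheless expected, a 2.6-fold lower number from compound 3 to compound 4 (0.41 log units; beyond the scatter), because compound 3 already sits at 1790 nM, the highest number in the set. For compound 4 the estimate in this assay is 700 nM, with a range from 150 nM to 3000 nM.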

Compound 4, half-maximal effective concentration: 0.2 nM
The estimate for compound 4 lay 3500-fold (3.54 log units) above the measured number; the measured number lies below the stated range.
By their numbers in this assay, from the lowest: compound 4; then compound 2; then compound 1; then compound 3.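

At the amide-type nitrogen, trading one five-membered aromatic ring with 2 hetero atoms for another gives the largest step in the series in this assay, a 9000-fold lower number from compound 3 to compound 4 (3.95 log units; beyond the scatter), so ring size and the count of hetero atoms do not alone set the number at this position. The 1H-pyrazol-5-yl group also outdoes the two other groups on this nitrogen, with a 260-fold lower number from compound 2 to compound 4 (2.41 log units; beyond the scatter) and a 2000-fold lower number from compound 1 to compound 4 (3.30 log units; beyond the scatter), which places compound 4 lowest of the four. No measurement at hand accounts for the size of this change.

The entering group differs from the leaving one in its hydrogen-bond donor, its methyl and its ring, and these compounds do not separate those differences. A 1H-imidazol-2-yl group, or a pyrazole with a methyl on its ring nitrogen, would bear on that question.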